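Swapping the Hexyl Amide of an Inactive Compound for an Acid

This account rests on a few compounds, and the source may have more. Where it says the series, first, only, none or still open, it means among the compounds named here.

In a functional assay on OVCAR-3 cells (Homo sapiens) for antiproliferative activity (on this read-out higher numbers stand for weaker inhibition of growth and lower numbers for stronger inhibition of growth), compound 1 `CCCCCCNC(=O)c1cc(CCc2cc(O)ccc2O)ccc1O` gives 2400 nM, and compound 3 `COC(=O)c1cc(/C=C\c2cc(OC)ccc2OC)ccc1OC` gives 4900 nM. Compound 2 `CCCCCCNC(=O)c1cc(C#Cc2cc(OC)ccc2OC)ccc1OC` reads > 100000 nM, which is a limit of the assay and not a number. Compound 2 therefore has no exact position on this scale.

Compound 4 `COc1ccc(OC)c(C#Cc2ccc(OC)c(C(=O)O)c2)c1` differs from compound 2 at one place: hydroxy in place of hexylamino on a carbonyl carbon. In words, hydroxy stands in place of hexylamino on a carbonyl carbon. For the measured compounds named here, no measured pair of compounds shows this exact change, so the expectation rests on indirect evidence. Compound 3 also lacks the hexylamino group and reaches 4900 nM, although it differs from compound 4 in other ways too. That gives modest grounds to expect some measurable growth inhibition, but not a large gain. A small step toward stronger inhibition is expected, estimated as an at least 2.0-fold lower number from compound 2 to compound 4 (0.30 log units; that floor lies within the scatter). The expected value for compound 4 is 50000 nM, within an estimated range of 12000 nM to 100000 nM.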

Compound 4, concentration for 50% growth inhibition: 24400 nM
Estimate against measurement, compound 4: 2.0-fold (0.31 log units) above, within the range that was stated.
By their numbers in this assay, from the lowest: compound 1; then compound 3; then compound 4. At a limit, above all of these: compound 2.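

On this carbonyl carbon, the hexylamino group is not required for measurable growth inhibition in this assay: putting hydroxy in its place gives an at least 4.0-fold lower number from compound 2 to compound 4 (0.61 log units; beyond the scatter). For the compounds shown here, this is the first direct view of the change, as none of the earlier compounds formed a pair differing in only one place. The step is only a floor and its full size cannot be read, because compound 2 stands at a limit of the assay and not at a number: the limit of > 100000 nM in this assay, at which 1 of the 4 values shown sits.

The compounds shown leave open whether a shorter butylamino group, or a plain amino group, on the same carbonyl carbon would read closer to compound 4 or to compound 2. They also leave open whether hydroxy in place of hexylamino would act in the same direction on the core of compound 1, since this single pair speaks only for the core of compound 2.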